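The source may hold more compounds than are shown below. What is called first, only, known or untested is meant among the compounds shown, and "the series" means these compounds.

Measured so far: compound 1 `Nc1cc(C(F)(F)F)c(Br)nc1C(=O)NCCC(F)(F)F` with 40 nM; compound 2 `Nc1cc(C(F)(F)F)c(Br)nc1C(=O)NC[C@H](O)C(F)(F)F` with 23 nM.

Both numbers come from an assay on CHO cells for positive allosteric modulation of Cystic fibrosis transmembrane conductance regulator variant F508del (Homo sapiens), using a membrane potential dye, with a stated time of 30 min, in the presence of a further agent that is not named here; on this read-out lower numbers stand for an effect already at smaller amounts and higher numbers for an effect only at larger amounts of compound. Compound 2 holds the lowest of the two numbers, but its nearest neighbour is compound 1, and the step of a 1.7-fold lower number from compound 1 to compound 2 (0.24 log units; within the scatter) lies within the scatter, so the two are not separable on this read-out.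

Compound 3 `Nc1cc(C(F)(F)F)c(Br)nc1C(=O)NC[C@@H](O)C(F)(F)F` is the unmeasured partner. Compared with compound 2, (the two compounds have the same atoms and bonds and differ only in configuration as drawn: 1 of 1 stereo elements differ; a stereocentre at a saturated chain carbon is drawn S in compound 2 and R in compound 3). Among the measured compounds shown here, no measured step concerns a change of configuration at the stereocentre; the single step on hand, from compound 1 to compound 2, adds the hydroxy and says nothing about which drawn arrangement of it is preferred. There is therefore no basis for expecting a step in either direction beyond the scatter, but also none for ruling one out, so the range is kept wide.

For compound 3 the expected number in this assay is 35 nM, with a range of 10 nM to 150 nM, which as a step means an estimated 1.5-fold higher number from compound 2 to compound 3 (0.18 log units; within the scatter).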

Compound 3, half-maximal effective concentration: 9 nM
Compound 3: middle estimate off by 3.9-fold (0.59 log units), on the high side; the whole stated range lies above it.
By their numbers in this assay, from the lowest: compound 3; then compounds 2 and 1 (each within the scatter of the next).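

In this assay, the drawn configuration at the hydroxy-bearing saturated chain carbon now separates two compounds, with a 2.6-fold lower number from compound 2 to compound 3 (0.41 log units; beyond the scatter). Hydroxy in place of hydrogen had stayed within the scatter in the S arrangement, but in the R arrangement it gives a 4.4-fold lower number from compound 1 to compound 3 (0.65 log units; beyond the scatter), so at this position the effect of the replacement depends on configuration. The gap between the two alcohols can be assigned to the stereocentre alone, because nothing else varies: the fact that compounds 2 and 3 differ only in the configuration as drawn.

From the compounds shown here alone, whether an amine or a methoxy group on the same carbon would show a similar preference for the R arrangement remains open. So does whether the preference survives with a longer chain in place of the present one, since all three compounds share the same terminal trifluoromethyl group.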